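Cyclopropylcarbonyl in place of furoyl on the compound 1 scaffold

The source may hold more compounds than are shown below. What is called first, only, known or untested is meant among the compounds shown, and "the series" means these compounds.

Compound 1 `Cc1cccc(Cn2c(OC3CCN(C(=O)c4ccco4)CC3)nc3ccccc32)c1` is the reference point. In an assay on isolated protein for inhibition of aldehyde dehydrogenase 1A1 (Homo sapiens), read by spectrophotometry, tested at 10 uM (a higher number here means more inhibition at the concentration tested (going by the name of the read-out), a lower number less inhibition), compound 1 gives 68.3%, the highest of the three numbers recorded; compound 3 `O=C(C1CC1)N1CCN(Cc2nc3ccccc3n2Cc2ccc(Cl)cc2)CC1` gives 56.6% and compound 2 `COc1cccc(Cn2c(CN3CCN(C(=O)C4CC4)CC3)nc3ccccc32)c1` gives 44.4%, both beyond the scatter below compound 1. Going by the values given here, the single measured step, a number 12.2 percentage points higher from compound 2 to compound 3 (beyond the scatter), concerns the aryl on the saturated chain carbon bound to an aromatic nitrogen and leaves the carbonyl substituent untouched.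

Compound 4 `Cc1cccc(Cn2c(OC3CCN(C(=O)C4CC4)CC3)nc3ccccc32)c1` is the one to be measured. It differs from compound 1 by cyclopropyl in place of furan-2-yl on a carbonyl carbon. Among the compounds with values here, no measured step bears directly on this change: compound 2 and compound 3 already carry a cyclopropylcarbonyl, but they also differ from compound 1 in the linker to the shared core, so their lower values cannot be assigned to the carbonyl group alone. The expectation is therefore a step of a number 10.3 percentage points lower from compound 1 to compound 4 (beyond the scatter) in this assay, a modest loss that may not clear the scatter. Compound 4 is estimated at 58%, within 40% to 76%.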

Compound 4, a percentage reported as inhibition, at one concentration (the size of the read-out at that concentration, not a potency): 80.6%
The estimate for compound 4 lay 22.6 percentage points below the measured number; the measured number lies above the stated range.
By their numbers in this assay, from the lowest: compound 2; then compound 3; then compound 1; then compound 4.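

Furan-2-yl on the carbonyl carbon is not needed to hold the read-out in this assay: the swap to cyclopropyl gives a number 12.3 percentage points higher from compound 1 to compound 4 (beyond the scatter). Going by these compounds alone, this is the only measured step at this position, and it shows that with a smaller three-membered ring of carbon only, with no hydrogen-bond acceptor, there on the core of compound 1 the number is higher than with the furan-2-yl. Nothing available accounts for the direction or size of this step.

Still open, on these data alone, is whether an open-chain group such as isopropyl or a longer chain such as n-butyl, or a larger saturated ring such as cyclohexyl, on the same carbonyl carbon would keep or extend this gain. As far as these compounds go, it also remains open whether furan-2-yl and cyclopropyl rank the same way with the different linker of compound 2 and compound 3.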